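The source may report more compounds than this note shows. Statements on the series, on what has been measured and on what is new or still open speak of the compounds shown alone.

In a functional assay on HCT-116 cells (Homo sapiens) for inhibition, read by CCK-8 assay, with a stated time of 48 h (a lower number here means a stronger inhibitor, a higher number a weaker inhibitor), compound 1 (`COc1ccc(CN(C(=O)CSC(=S)N2CCOCC2)c2cc(OC)c(OC)c(OC)c2)cc1`) gives 4130 nM and compound 2 (`COc1ccc(CN(C(=O)CSC(=S)N2CCc3ccccc32)c2cc(OC)c(OC)c(OC)c2)cc1`) gives 7710 nM. Among the measured compounds shown here, the only measured step, a 1.9-fold higher number from compound 1 to compound 2 (0.27 log units; within the scatter), does not separate the two compounds, so compound 2 stands level with compound 1 on these numbers.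

Compound 3 (`COc1ccc(CN(C(=O)CN2CCN(C(C)=O)CC2)c2cc(OC)c(OC)c(OC)c2)cc1`) differs from compound 2 as follows: a group of 9 heavy atoms (6 carbon, 2 nitrogen, 1 oxygen; one six-membered non-aromatic ring with 2 hetero atoms) in place of a group of 12 heavy atoms (9 carbon, 1 nitrogen, 2 sulfur; one five-membered non-aromatic ring with 1 hetero atom, one six-membered aromatic ring of carbon only), on a saturated chain carbon bound to a carbonyl carbon. The entering group is 4-acetylpiperazin-1-yl, and the change lies on a saturated chain carbon bound to a carbonyl carbon.

The measured step bears on this change only in part. It exchanges one group on a thiocarbonyl carbon for another, and both measured compounds keep the sulfur atoms that leave here. For the measured compounds named here, no measured compound shows what their loss does, so neither direction can be favoured from the data. Going by the values given here, the single step of a 1.9-fold higher number from compound 1 to compound 2 (0.27 log units; within the scatter) gives no reason to expect a large shift, but it is thin support.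

The expected change is a 1.3-fold lower number from compound 2 to compound 3 (0.11 log units; within the scatter), with no shift beyond the scatter anticipated. In this assay the estimate for compound 3 is 6000 nM, with an expected range of 1800 nM to 20000 nM.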

Compound 3, half-maximal inhibitory concentration: > 20000 nM
Compound 3 gave a limit, no number; the forecaster's own chance of this, stated with the estimate: 10%; at least 3.3-fold (0.52 log units) between middle value and limit.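

In this assay compound 3 carries a limit of the assay and not a number: the limit of > 20000 nM in this assay, at which 1 of the 3 values shown sits.

On a saturated chain carbon bound to a carbonyl carbon, 4-acetylpiperazin-1-yl in place of the sulfur-bearing groups gives an at least 2.5-fold higher number from compound 2 to compound 3 (0.41 log units; beyond the scatter) and an at least 4.8-fold higher number from compound 1 to compound 3 (0.68 log units; beyond the scatter), and both steps lie beyond the scatter, whereas the earlier exchange on the thiocarbonyl carbon, a 1.9-fold higher number from compound 1 to compound 2 (0.27 log units; within the scatter), stayed within it. The series therefore now shows that replacing the whole group at this place can move the number measurably, which the two sulfur-bearing compounds alone could not show.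

The true size of both new steps stays open, since they rest on a limit, and the compounds shown do not separate the loss of the two sulfur atoms and the thiocarbonyl from the entry of the acetylpiperazine. A piperazine with a free ring amine or a methyl group in place of the acetyl, or a thioether chain ending in the same 4-acetylpiperazin-1-yl, would help to tell these two parts of the change apart.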